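The compounds below may be only part of what the source reports. "The series", "measured", "known", "first", "only" and "open" are said of these compounds alone.

Measured so far in a functional assay on HeLa cells (Homo sapiens) for inhibition, read by sulforhodamine B assay, with a stated time of 48 h; on this read-out higher numbers stand for weaker inhibition of growth and lower numbers for stronger inhibition of growth:
compound 1 `O=C(CCCCCc1ccccc1)OCC1COCCOCCOCCOCCOCCO1` — 79000 nM
compound 2 `O=C(OCC1COCCOCCOCCOCCOCCO1)c1cccc(-c2ccc(Br)cc2)c1` — 7800 nM

Compound 1 gives the higher of the two numbers in this assay; compound 2 stands lower by a gap beyond the scatter. Compound 3 `O=C(/C=C/c1ccccc1)OCC1COCCOCCOCCOCCOCCO1` differs from compound 1 by 2-phenylethenyl in place of 5-phenylpentyl on a carbonyl carbon. For the measured compounds named here, no measured pair shows this change, so its size is unknown. Some downward step in this assay is expected, though smaller than the gap to compound 2, whose 7800 nM is the only lower number at hand. The expected step is a 2.6-fold lower number from compound 1 to compound 3 (0.42 log units; beyond the scatter). Compound 3 is estimated at 30000 nM, with a range from 8000 nM to 100000 nM.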

Compound 3, concentration for 50% growth inhibition: 48000 nM
For compound 3 the middle estimate is 1.6-fold (0.20 log units) below the measured one, and the stated range covers the measured number.
By their numbers in this assay, from the lowest: compound 2; then compounds 3 and 1 (each within the scatter of the next).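

On the carbonyl carbon of the shared core, 2-phenylethenyl in place of 5-phenylpentyl gives a 1.6-fold lower number from compound 1 to compound 3 (0.22 log units; within the scatter) in this assay. At this position, therefore, the two groups are not told apart, despite the fewer heavy atoms of 2-phenylethenyl and the added double bond outside the aromatic ring. No measurement available here bears on the reason for this result.

The step changes chain length and the double bond together, leaving their separate contributions unresolved. A saturated 2-phenylethyl group would separate them, while a longer chain would test the other direction.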